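From compound 2 to compound 4: amino for trifluoromethoxy

The compounds below may be only part of what the source reports. "The series", "measured", "known", "first", "only" and "open" are said of these compounds alone.

Measured in a physicochemical assay for solubility, at pH 7.4; on this read-out lower numbers stand for lower solubility and higher numbers for higher solubility
- Compound 1 (`Cc1cc(NC(=O)Nc2ccc(C)c(Cl)c2)c2ccccc2n1`) gives 300 nM
- Compound 2 (`Cc1cc(NC(=O)Nc2ccccc2OC(F)(F)F)c2ccccc2n1`) gives 4600 nM
- Compound 3 (`CCc1ccc(NC(=O)Nc2cc(C)nc3ccccc23)cc1`) gives 3300 nM

Compound 2 holds the highest number of the three, yet it lies within the scatter of compound 3, and both stand beyond the scatter from compound 1. Compound 4 (`Cc1cc(NC(=O)Nc2ccccc2N)c2ccccc2n1`) carries amino in place of trifluoromethoxy on an aromatic carbon, ortho to a large group (amino in place of trifluoromethoxy on an aromatic carbon). Going by the values given here, no step at a single place has been measured, so the expectation is loose. An upward step close to the edge of the scatter is expected (a 2.0-fold higher number from compound 2 to compound 4 (0.29 log units; within the scatter)). Compound 4 is estimated at 9000 nM (expected range 2500 nM to 30000 nM).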

Compound 4, solubility: 51800 nM
The estimate for compound 4 lay 5.8-fold (0.76 log units) below the measured number; measured number above the stated range.
By their numbers in this assay, from the lowest: compound 1; then compounds 3 and 2 (each within the scatter of the next); then compound 4.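

In this assay, the place on an aromatic carbon, ortho to a large group, proves sensitive to the group it carries: amino in place of trifluoromethoxy gives an 11-fold higher number from compound 2 to compound 4 (1.05 log units; beyond the scatter). Going by these compounds alone, this is the first step at a single place, and it lies beyond the scatter. Nothing measured on these compounds bears on what lies behind it.

From the compounds shown here alone, whether the step belongs to the entry of amino or to the departure of trifluoromethoxy stays open; a hydroxyl or a methoxy at this place would help separate the two. Also open, going by these compounds, is whether amino gives a similar step on the aromatic rings of compound 1 and compound 3.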